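The compounds below may be only part of what the source reports. "The series", "measured", "known", "first", "only" and "open" are said of these compounds alone.

Measured compounds:
Compound 1, `O=C(CN(c1nc(Cl)nc2[nH]cnc12)C1CC1)NCC(=O)OCc1ccccc1`, gives 27.2% in a functional assay on the whole organism (Tail, strain ICR) with Mus musculus as the target, in the tail flick test, with a stated time of 90 min, at a dose of 25 umol/kg by the oral route; a lower number here means a weaker effect, a higher number a stronger effect of the compound at the dose given.
Compound 2, `O=C(CN(c1ncnc2c1ncn2C1CCCCO1)C1CC1)N[C@@H](CCC(=O)OCc1ccccc1)C(=O)OCc1ccccc1`, gives 25.2% in this assay.
Compound 3, `CC[C@H](C)[C@H](NC(=O)CN(c1ncnc2c1ncn2C1CCCCO1)C1CC1)C(=O)OCc1ccccc1`, gives 22.6% in this assay.

Compound 1 holds the highest of the three numbers in this assay, yet compound 2 and compound 3 both lie within the scatter of it, so no order among the three can be read from these values.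

Compound 4, `NCCCC[C@H](NC(=O)CN(c1nc(Cl)nc2[nH]cnc12)C1CC1)C(=O)OCc1ccccc1`, differs from compound 1 in one place: 4-aminobutyl in place of hydrogen on a saturated chain carbon bound to an amide-type nitrogen and a carbonyl carbon. For the measured compounds named here, only one measured step touches the same place, that between two compounds whose core carries a different substitution than compound 1: a number 2.6 percentage points lower from compound 2 to compound 3 (within the scatter). There, exchanging one group for another on that carbon left the read-out within the scatter. Going by the values given here, the change to compound 4 brings in a group of a different kind, and no measured pair shows what a 4-aminobutyl group at this place does, so that step bears on it only loosely.

On this basis the step from compound 1 to compound 4 in this assay is expected to be small, a number 0.2 percentage points lower from compound 1 to compound 4 (within the scatter), with no direction beyond the scatter. Compound 4 is therefore estimated at 27%, in a range from 12% to 42%.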

Compound 4, a percentage reported as activity, at one dose (the size of the read-out at that dose, not a potency): 35.3%
Estimate against measurement, compound 4: 8.3 percentage points below; the measured number falls inside the stated range.
By their numbers in this assay, from the lowest: compounds 3, 2, 1 and 4 (each within the scatter of the next, the first and the last beyond it).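

For the compounds shown here, on the core of compound 1, this is the first step at the saturated chain carbon bound to an amide-type nitrogen and a carbonyl carbon that starts from hydrogen rather than from another side chain: in this assay, the step is a number 8.1 percentage points higher from compound 1 to compound 4 (within the scatter). Adding 4-aminobutyl at this place therefore leaves the read-out within the scatter, as did the exchange of one side chain for another on the different core, a number 2.6 percentage points lower from compound 2 to compound 3 (within the scatter), so neither step at this carbon gives a change that can be told from repeated measurement. Nothing measured here explains the size of the step from compound 1 to compound 4.

The compounds shown leave open whether the amine at the end of the chain and the four-carbon chain itself have separate effects at this place, since 4-aminobutyl is the only such group on this core. A plain butyl chain without the amine, a shorter aminoethyl chain or a carboxylic acid at the chain end would test this, and a step beyond the scatter at this carbon is still to be seen.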